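Methoxy to Chloro on a Pendant Phenyl Ring

The source may hold more compounds than are shown below. What is called first, only, known or untested is meant among the compounds shown, and "the series" means these compounds.

Measured compounds:
compound 1 `COc1cc(/C=C/C(=O)c2cccc(-n3cc(-c4ccccc4)[nH]c3=O)c2)ccc1O` 1400 nM
compound 2 `COc1ccc(-c2cn(-c3cccc(C(=O)/C=C/c4ccc(O)c(OC)c4)c3)c(=O)[nH]2)cc1` 1930 nM

In a functional assay on HCT-116 cells (Homo sapiens) for inhibition (on this read-out lower numbers stand for stronger inhibition of growth and higher numbers for weaker inhibition of growth), compound 2 gives 1930 nM, the higher of the two numbers, while compound 1 gives 1400 nM; the step of a 1.4-fold higher number from compound 1 to compound 2 (0.14 log units; within the scatter) lies within the usual scatter, so the two cannot be told apart.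

Compound 3 `COc1cc(/C=C/C(=O)c2cccc(-n3cc(-c4ccc(Cl)cc4)[nH]c3=O)c2)ccc1O` differs from compound 2 in one place: chloro in place of methoxy on an aromatic carbon. Read one bond further out, this is 4-methoxyphenyl to 4-chlorophenyl.

Among the compounds with values here, only one measured step bears on this position, a 1.4-fold higher number from compound 1 to compound 2 (0.14 log units; within the scatter), and it was within the scatter. Nothing directly tells how chloro compares with methoxy here. Within the data shown here, with the one available step showing little sensitivity at this position, the expected step of a 1.3-fold lower number from compound 2 to compound 3 (0.11 log units; within the scatter) is none beyond the scatter.

Compound 3 is therefore estimated at 1500 nM, with a range from 600 nM to 4000 nM.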

Compound 3, concentration for 50% growth inhibition: 1460 nM
Estimate against measurement, compound 3: 1.0-fold (0.01 log units) above; low and high end bracket the measured number.
By their numbers in this assay, from the lowest: compounds 1, 3 and 2 (each within the scatter of the next).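

In this assay, chloro in place of methoxy gives a 1.3-fold lower number from compound 2 to compound 3 (0.12 log units; within the scatter), and chloro in place of hydrogen gives a 1.0-fold higher number from compound 1 to compound 3 (0.02 log units; within the scatter). The earlier compounds compared only hydrogen with methoxy at this place on the ring; now a third group, chloro, joins them, and hydrogen, methoxy and chloro cannot be told apart on this read-out, so among these three compounds the choice of group makes no visible difference. No information is available here on why the three compounds read alike.

As far as these compounds go, it remains open whether any group at this place can move the number beyond the scatter. An amine, a carboxylic acid or a longer chain such as butoxy would test whether this insensitivity extends beyond these three small groups.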